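This account rests on a few compounds, and the source may have more. Where it says the series, first, only, none or still open, it means among the compounds named here.

Values measured so far in a functional assay on A549 cells (Homo sapiens) for inhibition, read by CCK-8 assay, with a stated time of 72 h (a higher number here means a weaker inhibitor, a lower number a stronger inhibitor), are these

- compound 1 `C[C@H]1O[C@@H]2C[C@@H](O)[C@@]1(O)c1c2c(O)c(C(N)=O)c2ncoc12` gives 7200 nM
- compound 2 `C[C@H]1O[C@@H]2C[C@@H](O)[C@@]1(O)c1c2c(O)c(C(N)=O)c2nc([C@@H](O)CO)oc12` gives 6400 nM

Compound 2 stands within the scatter of compound 1, so the two cannot be ranked. Compound 3 `C[C@H]1O[C@@H]2C[C@@H](O)[C@@]1(O)c1c2c(O)c(C(N)=O)c2nc([C@@H](O)[C@@H](O)CO)oc12` differs from compound 2 by a single change (hydroxymethyl in place of hydrogen on a saturated chain carbon bound to an oxygen on a saturated carbon and a saturated chain carbon), which can also be read as 1,2-dihydroxyethyl to 1,2,3-trihydroxypropyl. Within the data shown here, one measured step bears on it, the one with 1,2-dihydroxyethyl in place of hydrogen on an aromatic carbon (a 1.1-fold lower number from compound 1 to compound 2 (0.05 log units; within the scatter)), and that step stayed within the scatter. A further hydroxymethyl is therefore expected to bring no step beyond the scatter in this assay either, although a single step is thin support. The expected step is small (a 1.1-fold lower number from compound 2 to compound 3 (0.03 log units; within the scatter)). For compound 3 the estimated value is 6000 nM with an expected range from 3000 nM to 12000 nM in this assay.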

Compound 3, half-maximal inhibitory concentration: 4800 nM
The estimate for compound 3 lay 1.3-fold (0.10 log units) above the measured number; the range from low to high includes it.
By their numbers in this assay, from the lowest: compounds 3, 2 and 1 (each within the scatter of the next).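

In this assay, going from 1,2-dihydroxyethyl to 1,2,3-trihydroxypropyl gives a 1.3-fold lower number from compound 2 to compound 3 (0.12 log units; within the scatter), and 1,2,3-trihydroxypropyl in place of hydrogen on the aromatic carbon gives a 1.5-fold lower number from compound 1 to compound 3 (0.18 log units; within the scatter). So a further hydroxymethyl on the chain brings no step that can be read, and even the longer of the two chains shown cannot be told apart from hydrogen at this position. Nothing available here explains this flat result.

The compounds shown leave open whether a different kind of group on this aromatic carbon, such as an amine or a carboxylic acid, would bring a step beyond the scatter. They also leave open whether a plain alkyl chain without hydroxyl groups would do so.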